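Dithiocarbamate Amides: From Indoline to Methylpyridinylamine

This account rests on a few compounds, and the source may have more. Where it says the series, first, only, none or still open, it means among the compounds named here.

Three compounds were measured in a functional assay on A-375 cells (Homo sapiens) for antiproliferative activity, read by CCK-8 assay, with a stated time of 72 h, tested at 2 uM; a higher number here means a stronger effect of the compound at the concentration tested, a lower number a weaker effect. Compound 1 `Nc1ccccc1NC(=O)c1ccc(CSC(=S)N2CCN(c3ccccc3)CC2)cc1` gives 27.5% in this assay. Compound 2 `Nc1ccccc1NC(=O)c1ccc(CSC(=S)N2CCc3ccccc32)cc1` gives 25.7%, the lowest of the three numbers, although compound 1 lies within the scatter of it. Going by the values given here, compound 3 `Nc1ccccc1NC(=O)c1ccc(CSC(=S)N2CCN(c3cccnc3)CC2)cc1` gives 40.5%, and only that compound lies beyond the scatter of compound 2. Among the compounds with values here, the one measured step is a number 13 percentage points higher from compound 1 to compound 3 (beyond the scatter).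

Compound 4 `CN(C(=S)SCc1ccc(C(=O)Nc2ccccc2N)cc1)c1cccnc1` has not been measured. It differs from compound 2 in one place: methyl(pyridin-3-yl)amino in place of 2,3-dihydro-1H-indol-1-yl on a thiocarbonyl carbon. The step from compound 1 to compound 3 bears on this change, since a pyridin-3-yl group enters there as well, and it was modest in size. The change to compound 4 is not the same. In compound 2 the 2,3-dihydro-1H-indol-1-yl group leaves entirely and an open methyl(pyridin-3-yl)amino group enters, so the measured step is only a partial guide.

Compound 4 is therefore expected to show a modest rise, a step of a number 9.3 percentage points higher from compound 2 to compound 4 (within the scatter). The estimate for compound 4 in this assay is 35%, within a range from 22% to 50%.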

Compound 4, a percentage reported as inhibition, at one concentration (the size of the read-out at that concentration, not a potency): 26.5%
For compound 4 the middle estimate is 8.5 percentage points above the measured one, within the range that was stated.
By their numbers in this assay, from the lowest: compounds 2, 4 and 1 (each within the scatter of the next); then compound 3.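

In this assay, replacing 2,3-dihydro-1H-indol-1-yl with methyl(pyridin-3-yl)amino on the thiocarbonyl carbon gives a number 0.8 percentage points higher from compound 2 to compound 4 (within the scatter), so at this place the read-out does not separate the two groups, even though the group that enters has no five-membered ring and carries a hydrogen-bond acceptor that the group leaving lacks. The earlier compounds had shown a pyridin-3-yl group only as a replacement for phenyl on an amine nitrogen in a ring, with a number 13 percentage points higher from compound 1 to compound 3 (beyond the scatter), and the new result shows that a step of that kind does not appear whenever a pyridin-3-yl group enters, since here it comes with a different group leaving and a different attachment. No measurement offered here accounts for the difference between these two steps.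

The compounds shown leave open whether the methyl on the amine nitrogen plays any part, which an ethyl group or a hydrogen in its place would test. They also leave open whether a quite different group on the thiocarbonyl carbon, such as a morpholine ring or a plain dimethylamino group, would stand apart from compound 2 beyond the scatter.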